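The source may report more compounds than this note shows. Statements on the series, on what has been measured and on what is new or still open speak of the compounds shown alone.

Measured compounds in an assay on HEK293 cells for displacement of a labelled ligand from Neuronal acetylcholine receptor; alpha3/beta4 (Homo sapiens), read by scintillation counting; a lower number here means a stronger inhibitor, a higher number a weaker inhibitor:
- compound 1 `COc1ccc(O)cc1OC[C@@H]1CCCN1`: 7700 nM
- compound 2 `Oc1cccc(OC[C@@H]2CCCN2)c1`: 3800 nM

Compound 1 stands at the higher of the two numbers in this assay; its nearest neighbour is compound 2, and the step from compound 1 to compound 2 is a 2.0-fold lower number from compound 1 to compound 2 (0.31 log units; beyond the scatter), brought about by hydrogen in place of methoxy on an aromatic carbon.

Compound 3 `COc1ccccc1OC[C@@H]1CCCN1` is not yet measured in this assay. It differs from compound 1 by hydrogen in place of hydroxy on an aromatic carbon, so it keeps the methoxy group that compound 2 has lost and instead drops the hydroxy group. Among the compounds with values here, no measured pair shows exactly this change. Within the data shown here, the only step that bears on it at all, the one from compound 1 to compound 2, is modest and shows that stripping one substituent from the core of compound 1 lowered the number by a small margin. On that slim basis a step from compound 1 to compound 3 of a 1.3-fold lower number from compound 1 to compound 3 (0.11 log units; within the scatter) is expected, small and possibly within the scatter. Compound 3 is therefore estimated at 6000 nM, with a range from 2500 nM to 15000 nM.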

Compound 3, inhibition constant: 3600 nM
Estimate against measurement, compound 3: 1.7-fold (0.22 log units) above; the measured number falls inside the stated range.
By their numbers in this assay, from the lowest: compounds 3 and 2 (each within the scatter of the next); then compound 1.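

In this assay, taking the hydroxy group off the aromatic carbon that is para to a methoxy group gives a 2.1-fold lower number from compound 1 to compound 3 (0.33 log units; beyond the scatter), so the hydroxy group at this position is not needed to reach the lower number. Within the data shown here, compound 1 had so far been seen to lose only its methoxy group, with a 2.0-fold lower number from compound 1 to compound 2 (0.31 log units; beyond the scatter); now the loss of either substituent from the core of compound 1 is seen to lower the number, modestly but beyond the scatter each time. Nothing measured here offers an explanation for this step.

The compounds shown leave open whether an amine or a chlorine atom at this position would move the number in either direction. They also leave open what happens when hydroxy and methoxy are both replaced by hydrogen.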